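The compounds below may be only part of what the source reports. "The series", "measured", "known", "first", "only" and "open" are said of these compounds alone.

Working notes on the series

For the measured compounds named here, compound 3 `O=C(Nc1ccccc1Cl)N1CCC(c2nc(-c3ccc4ccccc4n3)no2)CC1` sits second highest of the three numbers so far in a functional assay on Shh Light II cells (Mus musculus) for inhibition, read by a luciferase reporter; a lower number here means a stronger inhibitor, a higher number a weaker inhibitor. Compound 3 gives 510 nM. Compound 2 `N#Cc1ccccc1NC(=O)N1CCC(c2nc(-c3ccc4ccccc4n3)no2)CC1` gives 190 nM, and compound 1 `Cc1noc(C)c1NC(=O)N1CCC(c2nc(-c3ccc4ccccc4n3)no2)CC1` gives 3000 nM. The steps that change the group on the amide-type nitrogen were a 16-fold lower number from compound 1 to compound 2 (1.20 log units; beyond the scatter) and a 5.9-fold lower number from compound 1 to compound 3 (0.77 log units; beyond the scatter), while the ring-substituent change was a 2.7-fold higher number from compound 2 to compound 3 (0.43 log units; beyond the scatter).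

Compound 4 `O=C(NCC1CCC1)N1CCC(c2nc(-c3ccc4ccccc4n3)no2)CC1` differs from compound 3 as follows: cyclobutylmethyl in place of 2-chlorophenyl on an amide-type nitrogen. Going by the values given here, no measured step yet replaces an aromatic ring at this nitrogen with a saturated carbon chain, so the two steps from compound 1 only show that this nitrogen tolerates a swap of one ring for another with a modest to large shift in the number. Without a direct precedent, a step beyond the scatter in the upward direction is expected, estimated as a 3.9-fold higher number from compound 3 to compound 4 (0.59 log units; beyond the scatter). Compound 4 is therefore expected to give 2000 nM, with a range from 600 nM to 7000 nM.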

Compound 4, half-maximal inhibitory concentration: 410 nM
Compound 4: middle estimate off by 4.9-fold (0.69 log units), on the high side; measured number below the stated range.
By their numbers in this assay, from the lowest: compound 2; then compounds 4 and 3 (each within the scatter of the next); then compound 1.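

In this assay, an aromatic ring on the amide-type nitrogen proves not to be required: cyclobutylmethyl in place of 2-chlorophenyl gives a 1.2-fold lower number from compound 3 to compound 4 (0.09 log units; within the scatter), so these two groups cannot be told apart in this read-out. The same saturated group is not equivalent to every aromatic group at this nitrogen, with a 2.2-fold higher number from compound 2 to compound 4 (0.33 log units; beyond the scatter) against 2-cyanophenyl and a 7.3-fold lower number from compound 1 to compound 4 (0.86 log units; beyond the scatter) against 3,5-dimethyl-1,2-oxazol-4-yl, so the group at this position still matters, but aromatic versus saturated does not by itself sort the four numbers. Nothing measured is available to account for these steps.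

Still open, on these data alone, is whether a longer open carbon chain, a cyclohexyl ring or a chain ending in an amine on this nitrogen would stay close to compound 4 . An unsubstituted phenyl at the same place would also show how much of the gap between the aromatic groups depends on the chloro and cyano substituents.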